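The source may hold more compounds than are shown below. What is called first, only, known or untested is meant among the compounds shown, and "the series" means these compounds.

Measured so far:
- compound 1 `CNCc1cn(S(=O)(=O)c2cccs2)c(-c2cccnc2F)c1F`: 42 ng.h/mL
- compound 2 `CNCc1cn(S(=O)(=O)c2ncccc2C)c(-c2cccnc2F)c1F`: "not determined" (no result reported)

In an ADME assay on the whole organism (plasma, Rattus norvegicus, strain Sprague-Dawley) for pharmacokinetics, read by LC-MS, using cassette dosing, at a dose of 0.2 mg/kg by the intravenous route (a lower number here means less compound in the circulation, a higher number more compound in the circulation at the dose given), compound 2 has no number to stand on, its entry reading "not determined" (no result reported). Compound 3 `CNCc1cn(S(=O)(=O)c2cccc(C)n2)c(-c2cccnc2F)c1F` is the next to be measured. The structural change is 6-methylpyridin-2-yl in place of 3-methylpyridin-2-yl on a sulfonyl sulfur, with 6-methylpyridin-2-yl in place of 3-methylpyridin-2-yl on a sulfonyl sulfur. Going by the values given here, no measured step exists for this change, so the expectation is of no shift beyond the scatter in this assay, and the only anchor is compound 1 at 42 ng.h/mL. For compound 3 the expected value is 40 ng.h/mL, with an estimated range of 15 ng.h/mL to 100 ng.h/mL.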

Compound 3, area under the concentration-time curve: 41 ng.h/mL
For compound 3 the middle estimate is 1.0-fold (0.01 log units) below the measured one, and the stated range covers the measured number.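

In this assay the replacement of thiophen-2-yl by 6-methylpyridin-2-yl on the sulfonyl sulfur gives a 1.0-fold lower number from compound 1 to compound 3 (0.01 log units; within the scatter), so at this position the two rings read alike. Compound 2 has no number, so the step between 3-methylpyridin-2-yl and 6-methylpyridin-2-yl cannot be read. No measurement here bears on why the two rings read alike. Open, going by these compounds, is whether the same holds for phenyl, or for a pyridine ring carrying a carboxylic acid or an amine, and whether the methyl matters in this ring at all.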